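This account rests on a few compounds, and the source may have more. Where it says the series, first, only, none or still open, it means among the compounds named here.

Measured compounds:
Compound 1, `N#CC1=C(NCC(=O)O)N(c2ccccc2)C(=O)N2CCCCC(N3CCCC3)C12`: 67.2%
Compound 2, `N#CC1=C(/N=C/c2ccccc2)N(c2ccccc2)C(=O)N2CCCCC(N3CCCC3)C12`: 46.5%
Compound 3, `COc1ccc(/C=N/C2=C(C#N)C3C(N4CCCC4)CCCCN3C(=O)N2c2ccccc2)cc1`: 59.1%

All three were tested in a functional assay on the whole organism (strain albino) for inhibition, with Rattus norvegicus as the target, read by paw edema, with a stated time of 1 h, at a dose of 20 mmol/kg by the intraperitoneal route; a lower number here means less inhibition, a higher number more inhibition at the dose given (going by the name of the read-out). Compound 3 stands second highest of the three numbers: its gap to compound 1 lies within the scatter, while the step of a number 12.6 percentage points higher from compound 2 to compound 3 (beyond the scatter) lies beyond it.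

Compound 4, `N#CC1=C(N)N(c2ccccc2)C(=O)N2CCCCC(N3CCCC3)C12`, has not yet been tested. Its difference from compound 3 is one nitrogen atom in place of a group of 10 heavy atoms (8 carbon, 1 nitrogen, 1 oxygen; one six-membered aromatic ring of carbon only), on a double-bonded ring carbon. Among the measured compounds shown here, no measured step swaps this same pair of groups. The nearest guides are the two steps that altered the same double-bonded ring carbon: a number 20.7 percentage points lower from compound 1 to compound 2 (beyond the scatter) and a number 8.1 percentage points lower from compound 1 to compound 3 (within the scatter). In both, a larger group carrying an aromatic ring replaced a smaller group without a ring; the first lowered inhibition beyond the scatter, the second stayed within it. Compound 4 carries the smallest of the four groups at that ring carbon, and the three measured numbers themselves span only a modest band. The step of a number 4.1 percentage points lower from compound 3 to compound 4 (within the scatter) is therefore expected to stay within the scatter, with no clear direction. Compound 4 is estimated at 55%, within a range from 38% to 72%.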

Compound 4, a percentage reported as inhibition, in the whole organism at one dose (the size of the read-out at that dose, not a potency): 77.9%
Estimate against measurement, compound 4: 22.9 percentage points below; the whole stated range lies below it.
By their numbers in this assay, from the lowest: compound 2; then compounds 3 and 1 (each within the scatter of the next); then compound 4.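

In this assay, the bare amino group on the double-bonded ring carbon gives the highest number of the four compounds, and each comparison is clear: a number 10.7 percentage points higher from compound 1 to compound 4 (beyond the scatter), a number 18.8 percentage points higher from compound 3 to compound 4 (beyond the scatter), and a number 31.4 percentage points higher from compound 2 to compound 4 (beyond the scatter). The earlier compounds shown here could only be compared with one another, all carrying something on this nitrogen; compound 4 supplies the reference without such a group, and each of the three added groups, carboxymethyl and the two with an aromatic ring, comes with a lower number than that reference. Large groups with an aromatic ring give the lowest numbers here, but the carboxymethyl of compound 1 also falls short of the amino group, so ring-free substitution is not free of loss either, and no measurement shown accounts for any of these differences.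

The compounds shown leave open whether a very small group on this nitrogen, such as methyl or acetyl, would keep the number of compound 4 or lower it. They also leave open how a longer chain ending in a carboxylic acid would compare with carboxymethyl, and how these compounds rank at other doses.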